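Indolylmethyl in Place of Phenyl on a Macrocyclic Ring

This account rests on a few compounds, and the source may have more. Where it says the series, first, only, none or still open, it means among the compounds named here.

Compound 1 `CCC[C@@H]1NC(=O)[C@@H](C(C)C)NC(=O)[C@@H](CCCCN)NCCOc2ccccc2/C=C/CNC1=O`: in an assay on isolated protein for displacement of a labelled ligand from Motilin receptor (Homo sapiens) (a lower number here means a stronger inhibitor, a higher number a weaker inhibitor), compound 1 gives > 10000 nM, which is a limit of the assay rather than a number.
Compound 2 `CCC[C@@H]1NC(=O)[C@@H](C(C)C)NC(=O)[C@@H](Cc2ccccc2)NCCOc2ccccc2CCCNC1=O`: compound 2 gives 57 nM.
Compound 3 `CCC[C@@H]1NC(=O)[C@@H](C(C)C)NC(=O)[C@@H](c2ccccc2)NCCOc2ccccc2CCCNC1=O`: compound 3 gives > 10000 nM, again a limit of the assay.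

Compound 3 therefore stands at a limit only, and it shares that position with compound 1, as the limit of > 10000 nM in this assay, at which 2 of the 3 values shown sit, shows. Going by the values given here, compound 2 is the single compound with a measured number. Among the compounds with values here, the one step that separates a number from a limit is an at least 170-fold higher number from compound 2 to compound 3 (2.24 log units; beyond the scatter): taking the benzyl of compound 2 down to a phenyl set directly on the saturated ring carbon wipes out the measurable binding.

Compound 4 `CCC[C@@H]1NC(=O)[C@@H](C(C)C)NC(=O)[C@@H](Cc2c[nH]c3ccccc23)NCCOc2ccccc2CCCNC1=O` differs from compound 3 by (1H-indol-3-yl)methyl in place of phenyl on a saturated ring carbon. Within the data shown here, the entering (1H-indol-3-yl)methyl group is, like the benzyl of compound 2, an aromatic system attached through a methyl linker, so the only measured step that bears on this change is an at least 170-fold higher number from compound 2 to compound 3 (2.24 log units; beyond the scatter), read in reverse. Among the measured compounds shown here, no measured pair covers indole against phenyl, so the size of any further shift is unknown. A large step toward stronger binding is expected, an at least 250-fold lower number from compound 3 to compound 4 (2.39 log units; beyond the scatter). Compound 4 is therefore estimated at 40 nM, with a range from 8 nM to 300 nM.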

Compound 4, inhibition constant: 255 nM
Beside the measured number, compound 4's estimate is 6.4-fold (0.80 log units) below it; low and high end bracket the measured number.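

At this ring carbon, the two compounds that carry an aromatic system through a methyl linker, compound 2 and compound 4, both give measured numbers, whereas compound 3, with phenyl set directly on the ring, does not, and the return of measurable binding is large: an at least 39-fold lower number from compound 3 to compound 4 (1.59 log units; beyond the scatter). That step is only a lower bound on the true change, because compound 3 sits at a limit of the assay and not at a number: the limit of > 10000 nM in this assay, at which 2 of the 4 values shown sit. The linker alone does not settle the outcome, since the aromatic system on it also counts, with the indole giving up a modest amount against the plain phenyl of the benzyl group: a 4.5-fold higher number from compound 2 to compound 4 (0.65 log units; beyond the scatter).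

The compounds shown leave open whether that modest difference follows from the second aromatic ring or from the indole ring nitrogen with its hydrogen, which a naphthylmethyl group on the same carbon would help to separate. They also leave open whether a longer chain, such as 2-phenylethyl, keeps binding at this carbon, or whether a hydroxyl group on the benzyl ring changes the number of compound 2.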